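The source may hold more compounds than are shown below. What is called first, only, known or untested is meant among the compounds shown, and "the series" means these compounds.

- Compound 1 `O=C(O)CC(NC(=O)c1ccc(F)cc1)c1ccc(Cl)cc1Cl`: 55800 nM
- Compound 2 `COc1ccccc1C(=O)NC(CC(=O)O)c1ccc(Cl)cc1Cl`: > 100000 nM

Both compounds were tested in a functional assay on MDA-MB-436 cells (Homo sapiens) for antiproliferative activity, read by MTT assay, with a stated time of 24 h; on this read-out lower numbers stand for stronger inhibition and higher numbers for weaker inhibition. Compound 2 gives > 100000 nM, which is a limit of the assay and not a number.

Compound 3 `O=C(O)CC(NC(=O)c1c(Cl)cccc1Cl)c1ccc(Cl)cc1Cl` has not yet been measured. It keeps the shared core of compound 2 and changes one group: 2,6-dichlorophenyl in place of 2-methoxyphenyl on a carbonyl carbon. In words, 2,6-dichlorophenyl takes the place of 2-methoxyphenyl on a carbonyl carbon.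

Going by the values given here, only one measured step changes this same place: an at least 1.7-fold higher number from compound 1 to compound 2 (0.25 log units; that floor lies within the scatter). Since that step gives only a floor, and the floor lies within the scatter, it offers no firm size or direction. Among the compounds with values here, the only true number nearby is from compound 1, at 55800 nM. In this assay, no step beyond the scatter is therefore expected, and the estimated change is an at least 1.2-fold lower number from compound 2 to compound 3 (0.09 log units; that floor lies within the scatter). Compound 3 is expected to give about 80000 nM, with an estimated range of 35000 nM to 180000 nM.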

Compound 3, half-maximal inhibitory concentration: > 100000 nM
Compound 3: no number, only a limit (the forecaster's own chance of this, stated with the estimate: 50%); at least 1.2-fold (0.09 log units) between middle value and limit.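

With compound 3, a second replacement for 4-fluorophenyl on a carbonyl carbon ends at the limit of the assay: the limit of > 100000 nM in this assay, at which 2 of the 3 values shown sit. Against the one true number here, the change reads as an at least 1.7-fold higher number from compound 1 to compound 3 (0.25 log units; that floor lies within the scatter) and so fixes no firm size or direction at this place. The step between the two compounds at the limit cannot be read, so 2,6-dichlorophenyl and 2-methoxyphenyl cannot be ranked in this assay on these values.

Going by these compounds, how far compound 2 and compound 3 lie past that limit stays open. Also open, on these data alone, is whether a group of another kind on this carbonyl carbon, such as an amine-bearing phenyl or a longer alkyl chain, would give a true number that stands clearly apart from compound 1 at 55800 nM on this read-out.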